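This account rests on a few compounds, and the source may have more. Where it says the series, first, only, none or still open, it means among the compounds named here.

Of the compounds shown here, three built on one shared core have been tested in a toxicity assay on HepG2 cells (Homo sapiens) for inhibition, read by CellTiter-Glo, with a stated time of 48 h; on this read-out lower numbers stand for stronger inhibition and higher numbers for weaker inhibition. Compound 1 `COc1ccc2nc(C)cc(OCC(=O)Nc3cc(C)cc(C)c3)c2c1` gives 20000 nM in this assay. Compound 2 `COc1ccc2nc(C)cc(OCC(=O)Nc3c(C)cccc3C)c2c1` reaches only a limit of the assay, > 100000 nM. Compound 3 `COc1cccc(NC(=O)COc2cc(C)nc3ccc(OC)cc23)c1` likewise sits at a limit of the assay, > 100000 nM. Compound 3 therefore stands with compound 2 at the upper edge of what this assay reports, and compound 1 alone gives a plain number. The not yet measured compound 4 `COc1ccc2nc(C)cc(OCC(=O)Nc3ccc(Cl)c(OC)c3)c2c1` differs from compound 3 in one place: chloro in place of hydrogen on an aromatic carbon. Of the measured steps, an at least 5.0-fold higher number from compound 1 to compound 3 (0.69 log units; beyond the scatter) and an at least 5.0-fold higher number from compound 1 to compound 2 (0.69 log units; beyond the scatter) each swapped the whole ring on the amide nitrogen, and a step that the two limits leave unreadable from compound 2 to compound 3 gives no usable size. None of them adds a chloro to a ring already measured, so the strongest guide is that compound 3 rests at the limit of > 100000 nM in this assay, at which 2 of the 3 values shown sit. The step of an at least 1.2-fold lower number from compound 3 to compound 4 (0.09 log units; that floor lies within the scatter) is expected to be small, if it can be read at all. Compound 4 is estimated at 80000 nM, between 25000 nM and 300000 nM.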

Compound 4, half-maximal inhibitory concentration: > 100000 nM
Compound 4 gave a limit, no number (the forecaster's own chance of this, stated with the estimate: 60%); middle value at least 1.2-fold (0.09 log units) from the limit.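

In this assay compound 4, which carries a chloro on an aromatic carbon ortho to a methoxy group and para to a large group, gives > 100000 nM and that is a limit of the assay, not a number. The steps to compound 4 from compound 2 and from compound 3 join two limits and cannot be read, so adding this chloro to the 3-methoxyphenyl ring has no readable size. Among these compounds, the one step that can be read is an at least 5.0-fold higher number from compound 1 to compound 4 (0.69 log units; beyond the scatter) and it swaps the whole ring on the amide nitrogen, while the values now gather at one edge of the assay: the limit of > 100000 nM in this assay, at which 3 of the 4 values shown sit.

Among the compounds shown here, it stays open whether a chloro would shift the value on the ring of compound 1, the only compound here with a plain number. Going by these compounds, how an amine or a carboxylic acid at this same ring carbon would read also stays open.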